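The source may hold more compounds than are shown below. What is called first, only, known or untested is meant among the compounds shown, and "the series" means these compounds.

Compound 1 `O=C(NCc1cccc(Br)c1)N1C(=O)c2ccccc2S1(=O)=O`: 0.492 h
Compound 2 `Cc1ccccc1CNC(=O)N1C(=O)c2ccccc2S1(=O)=O`: 0.792 h

In a physicochemical assay for pharmacokinetics (on this read-out higher numbers stand for a longer-lived compound and lower numbers for a shorter-lived compound), compound 2 gives 0.792 h, and it stands within the scatter of compound 1, at 0.492 h. Two numbers offer only a narrow view. Compound 3 `O=C(NCc1ccc(Br)cc1)N1C(=O)c2ccccc2S1(=O)=O` has not been measured yet. It carries 4-bromophenyl in place of 2-methylphenyl on a saturated chain carbon bound to an amide-type nitrogen.

Among the measured compounds shown here, only one measured step bears on this change: a 1.6-fold higher number from compound 1 to compound 2 (0.21 log units; within the scatter). That step also links 2-methylphenyl to a phenyl group carrying bromine, though not to 4-bromophenyl itself, so it is a partial guide. It stayed within the scatter, and no step beyond the scatter is therefore expected in this assay. The expected step is a 1.3-fold lower number from compound 2 to compound 3 (0.12 log units; within the scatter). The estimate for compound 3 is 0.6 h, with an expected range of 0.3 h to 1.2 h.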

Compound 3, half-life: 0.187 h
Beside the measured number, compound 3's estimate is 3.2-fold (0.51 log units) above it; measured number outside the range, below it.
By their numbers in this assay, from the lowest: compound 3; then compounds 1 and 2 (each within the scatter of the next).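

In this assay, the group on a saturated chain carbon bound to an amide-type nitrogen now proves able to move the half-life by more than the scatter: putting 4-bromophenyl in place of 2-methylphenyl gives a 4.2-fold lower number from compound 2 to compound 3 (0.63 log units; beyond the scatter). The bromine's place on the phenyl ring also counts, since 4-bromophenyl in place of 3-bromophenyl gives a 2.6-fold lower number from compound 1 to compound 3 (0.42 log units; beyond the scatter), a change that keeps the same atoms and alters only their arrangement. No measurement here explains why either change shortens the half-life.

The compounds shown leave open whether the shorter half-life belongs to bromine specifically or would appear with other groups in the same ring position. A 4-methylphenyl or 4-chlorophenyl group at this place would help to separate those two readings.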